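The source may hold more compounds than are shown below. What is called first, only, known or untested is meant among the compounds shown, and "the series" means these compounds.

Working notes on the series in a functional assay on Ehrlich cells (Mus musculus) for cytotoxicity, read by trypan blue exclusion, with a stated time of 2 h, tested at 25 ug/mL; on this read-out higher numbers stand for a stronger effect at the one concentration tested and lower numbers for a weaker effect. Compound 1 `COc1ccc(C2C(C#N)=C(N)N(c3ccc(S(N)(=O)=O)cc3)C3=C2CCCC3)cc1` gives 90% and stands highest of the three numbers at hand. Compound 2 `COc1ccc2ccccc2c1C1C(C#N)=C(N)N(c2ccc(S(N)(=O)=O)cc2)C2=C1CCCC2` gives 10% and compound 3 `COc1ccc(C2C(C#N)=C(N)N(c3ccc(S(N)(=O)=O)cc3)C3=C2CCCC3)c2ccccc12` gives 5%; both lie far below compound 1, beyond the scatter. No pair among these three differs in only one place, so no single step has been measured within the set.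

Compound 4 `N#CC1=C(N)N(c2ccc(S(N)(=O)=O)cc2)C2=C(CCCC2)C1c1cccs1` is not yet measured. It differs from compound 1 as follows: thiophen-2-yl in place of 4-methoxyphenyl on a saturated ring carbon. Within the data shown here, no measured step speaks to this change, so the direction is open; a moderate drop is expected rather than none. The estimated step from a number 30 percentage points lower from compound 1 to compound 4 (beyond the scatter) is set accordingly. Compound 4 is thus expected to give 60%, within a range of 25% to 90%.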

Compound 4, a percentage reported as activity, at one concentration (the size of the read-out at that concentration, not a potency): 5%
The estimate for compound 4 lay 55 percentage points above the measured number, outside the stated range (below it).
By their numbers in this assay, from the lowest: compounds 3, 4 and 2 (each within the scatter of the next); then compound 1.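

In this assay, among these compounds, thiophen-2-yl in place of 4-methoxyphenyl on this saturated ring carbon gives a number 85 percentage points lower from compound 1 to compound 4 (beyond the scatter) and is the first single change measured. On the core of compound 1, the read-out therefore depends strongly on the group at this carbon, and one aromatic ring cannot replace the other here without a large loss. No measurement at hand accounts for this step. The data do not separate the part played by the methoxy group from that of the ring itself. Plain phenyl or furan-2-yl at this carbon would address that question.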